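Estimating a pyridyl alkene analogue from a hydroxypyridyl alkyne series

This account rests on a few compounds, and the source may have more. Where it says the series, first, only, none or still open, it means among the compounds named here.

Measured compounds:
compound 1 `Cc1ccc(-n2nccn2)c(C(=O)N2C[C@H](C#Cc3cccnc3)CC[C@H]2C)c1`: 41 nM
compound 2 `Cc1ccc(-n2nccn2)c(C(=O)N2C[C@H](C#Cc3ccc(CO)nc3)CC[C@H]2C)c1`: 150 nM
compound 3 `Cc1ccc(-n2nccn2)c(C(=O)N2C[C@H](C#Cc3cnccc3O)CC[C@H]2C)c1`: 7.5 nM

In an assay on cells for binding affinity to Orexin receptor type 2 (Homo sapiens), read by radioligand binding (on this read-out lower numbers stand for stronger inhibition and higher numbers for weaker inhibition), compound 3 has the lowest number of the three, the steps to it being a 5.5-fold lower number from compound 1 to compound 3 (0.74 log units; beyond the scatter) and a 20-fold lower number from compound 2 to compound 3 (1.30 log units; beyond the scatter). Compound 4 `Cc1ccc(-n2nccn2)c(C(=O)N2C[C@H](/C=C\c3ccc(F)cn3)CC[C@H]2C)c1` arises from compound 3 by the change (2-(5-fluoropyridin-2-yl)ethenyl in place of 2-(4-hydroxypyridin-3-yl)ethynyl on a saturated ring carbon). Among the measured compounds shown here, the only step that bears directly on it is the reverse of a 5.5-fold lower number from compound 1 to compound 3 (0.74 log units; beyond the scatter), since the hydroxy that compound 3 carries is gone in compound 4; the new ring and linker have no measured counterpart. A higher number is therefore expected for compound 4 in this assay, roughly a 5.3-fold higher number from compound 3 to compound 4 (0.73 log units; beyond the scatter), with the estimate 40 nM and a range from 10 nM to 160 nM.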

Compound 4, inhibition constant: 28 nM
The estimate for compound 4 lay 1.4-fold (0.15 log units) above the measured number, within the range that was stated.
By their numbers in this assay, from the lowest: compound 3; then compounds 4 and 1 (each within the scatter of the next); then compound 2.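

At this saturated ring carbon, the 2-(5-fluoropyridin-2-yl)ethenyl group, which carries no hydroxy, reads level with 2-(pyridin-3-yl)ethynyl in this assay, at a 1.5-fold lower number from compound 1 to compound 4 (0.17 log units; within the scatter). It still trails 2-(4-hydroxypyridin-3-yl)ethynyl, at a 3.7-fold higher number from compound 3 to compound 4 (0.57 log units; beyond the scatter), yet improves on 2-(6-(hydroxymethyl)pyridin-3-yl)ethynyl, at a 5.4-fold lower number from compound 2 to compound 4 (0.73 log units; beyond the scatter). No available evidence bears on these steps.

The ethenyl linker, the fluorine and the ring attachment all change together, so their separate shares remain unresolved. On these data alone, how an amino or methoxy group on the pyridine ring would read also stays open.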